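A few compounds are considered here, and "the series" means these few. Any claim that something is new, unique, unknown or untested is made for them only; others in the source may bear on it.

Of the compounds shown here, two have so far been measured in an assay on MDA-MB-231 cells for binding affinity to C-X-C chemokine receptor type 4 (Homo sapiens), read by immunofluorescence and microscopy, with stated times of 10 min and 30 min; on this read-out higher numbers stand for an effect only at larger amounts of compound and lower numbers for an effect already at smaller amounts. Compound 1 `Cc1ccc(S(=O)(=O)NCc2ccc(CNC(=O)c3ccc(Cl)cc3)cc2)cc1` gives 10 nM in this assay. Compound 2 `Cc1ccc(S(=O)(=O)NCc2ccc(CNC(=O)c3ccccc3Cl)cc2)cc1` gives 10 nM in this assay, and the step of no change at the digits printed from compound 1 to compound 2 (within the scatter) leaves compound 2 level with compound 1 at the digits shown. Compound 3 `O=C(NCc1ccc(CNS(=O)(=O)c2ccccc2)cc1)c1ccccc1Cl` is the compound to be measured next. It differs from compound 2 in a single place: hydrogen in place of methyl on an aromatic carbon. Among the measured compounds shown here, no measured step concerns this part of the shared core. For the measured compounds named here, the one step known, no change at the digits printed from compound 1 to compound 2 (within the scatter), concerns the 2-chlorophenyl in place of 4-chlorophenyl on a carbonyl carbon, and it brought no change beyond the scatter. Going by the values given here, there is thus no direct guide in the numbers for removing a methyl group; the only footing is that the one change tried so far left the read-out where it was. On that footing the expected step of no change at the digits printed from compound 2 to compound 3 (within the scatter) is none beyond the scatter, held with a wide margin. Compound 3 is therefore estimated to give 10 nM in this assay, with a likely range from 3 nM to 35 nM.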

Compound 3, effective concentration (reported as EC, without a stated level of effect): 10 nM
Estimate against measurement, compound 3: no gap at the digits printed, within the range that was stated.
By their numbers in this assay, from the lowest: compounds 1, 2 and 3 (each within the scatter of the next).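

In this assay, the change from 4-methylphenyl to phenyl brings no change at the digits printed from compound 2 to compound 3 (within the scatter). Among the compounds shown here, this is the first look at this end of the molecule, since the earlier step only moved the chlorine from one place to another on the chlorophenyl group attached to the carbonyl carbon, and it shows that the methyl group, a single carbon atom, can be replaced by hydrogen on this aromatic carbon with the read-out staying within the scatter, at least when 2-chlorophenyl is present on the carbonyl carbon. Nothing available gives a measured property that could explain why the read-out holds here.

The compounds shown leave open whether a group larger than methyl or of another kind on this same aromatic carbon, such as an amine, a carboxylic acid or a longer chain like butyl, would leave the read-out in place or shift it. They also leave open whether removing the methyl group would give the same result with 4-chlorophenyl on the carbonyl carbon, as in compound 1.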